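A few compounds are considered here, and "the series" means these few. Any claim that something is new, unique, unknown or untested is made for them only; others in the source may bear on it.

Of the compounds shown here, three sharing one core have been measured in a functional assay on MCF7 cells (Homo sapiens) for antiproliferative activity, read by sulforhodamine B assay, with a stated time of 48 h; on this read-out lower numbers stand for stronger inhibition of growth and higher numbers for weaker inhibition of growth. Compound 1 `NS(=O)(=O)NCC1CCN(c2cc(-c3ccccc3)ncn2)CC1` gives 34300 nM, compound 2 `COc1ccc(-c2cc(N3CCC(CNS(N)(=O)=O)CC3)ncn2)cc1` gives 35300 nM, and compound 3 `NS(=O)(=O)NCCC1CCN(c2cc(-c3ccccc3)ncn2)CC1` gives 53200 nM. Compound 3 shows the highest of these three numbers, yet its gaps to the others fall within the usual scatter, so the three stand together. Compound 4 `NS(=O)(=O)NCCC1CCN(c2cc(-c3ccc(Cl)cc3)ncn2)CC1` differs from compound 3 by chloro in place of hydrogen on an aromatic carbon. The nearest guide is the aromatic substitution from compound 1 to compound 2, which gave a 1.0-fold higher number from compound 1 to compound 2 (0.01 log units; within the scatter); the chain change a 1.6-fold higher number from compound 1 to compound 3 (0.19 log units; within the scatter) also stayed within the scatter. A step within the scatter, a 1.1-fold lower number from compound 3 to compound 4 (0.03 log units; within the scatter), is therefore expected in this assay. Compound 4 is estimated at 50000 nM, between 22000 nM and 110000 nM.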

Compound 4, concentration for 50% growth inhibition: 19700 nM
Compound 4: middle estimate off by 2.5-fold (0.40 log units), on the high side; measured number outside the range, below it.
By their numbers in this assay, from the lowest: compounds 4, 1, 2 and 3 (each within the scatter of the next, the first and the last beyond it).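

In this assay, among these compounds, the change from phenyl to 4-chlorophenyl gives a 2.7-fold lower number from compound 3 to compound 4 (0.43 log units; beyond the scatter) and is the first step beyond the scatter, so this place on the aromatic ring does respond to what it carries. The methoxy step a 1.0-fold higher number from compound 1 to compound 2 (0.01 log units; within the scatter) stayed within the scatter, but it sits on the shorter chain, so the two steps cannot be compared directly. Nothing measured here explains the chloro step. From the compounds shown here alone, whether chloro gives the same step on the shorter chain of compound 1 remains open. So does what a fluoro, a nitrile or an amine would do at this place.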